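The source may report more compounds than this note shows. Statements on the series, on what has been measured and on what is new or still open speak of the compounds shown alone.

Compound 1 `COc1cccc(/C=C/C(=O)c2sc(Nc3cccc(C)c3)nc2C)c1` in a functional assay on PC-3 cells (Homo sapiens) for cytotoxicity, read by MTT assay (on this read-out lower numbers stand for stronger inhibition and higher numbers for weaker inhibition), gives > 25000 nM, which is a limit of the assay rather than a number.
Compound 2 `COc1cccc(/C=C/C(=O)c2sc(Nc3ccccc3)nc2C)c1` in this assay gives > 25000 nM, again a limit.
Compound 3 `COc1cccc(/C=C/C(=O)c2sc(Nc3ccccc3C)nc2C)c1` in this assay gives > 25000 nM, also a limit.

Compound 3 therefore stands where the two other compounds stand, at the limit (the limit of > 25000 nM in this assay, at which 3 of the 3 values shown sit), and no number separates it from them. The steps between the measured compounds, a step that the two limits leave unreadable from compound 1 to compound 2, a step that the two limits leave unreadable from compound 1 to compound 3 and a step that the two limits leave unreadable from compound 2 to compound 3, cannot be read in size; both ends of each step sit at that limit.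

Compound 4 `Cc1ccccc1Nc1nc(C)c(C(=O)/C=C/c2ccccc2Cl)s1` differs from compound 3 in one place: 2-chlorophenyl in place of 3-methoxyphenyl on a double-bonded chain carbon bound to a double-bonded chain carbon. Among the compounds with values here, none of the measured steps touches this place, so no measured step shows what size of change to expect here. Within the data shown here, the only guide is that every value shown so far is a limit. The step that the limit leaves unreadable from compound 3 to compound 4 is therefore expected to be small, with no direction beyond the scatter. Compound 4 is estimated at 30000 nM, between 8000 nM and 100000 nM, and most likely it will again be reported only as a limit.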

Compound 4, half-maximal inhibitory concentration: > 25000 nM
Compound 4 was reported as a limit (the forecaster's own chance of this, stated with the estimate: 75%); the middle value is on the limit's open side.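

The step from compound 3 to compound 4 cannot be read in size, because both compounds sit at the same limit: the limit of > 25000 nM in this assay, at which 4 of the 4 values shown sit.

The compounds shown leave open how strongly each of them really inhibits in this assay, and whether any of the changes among them matters at all.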